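Trading sec-butyl for pentyl on the shared core

This account rests on a few compounds, and the source may have more. Where it says the series, first, only, none or still open, it means among the compounds named here.

In a functional assay on the whole organism (strain Sprague-Dawley) for inhibition, with Rattus norvegicus as the target, with a stated time of 10 min (a lower number here means that less compound is needed, a higher number that more compound is needed for the effect), compound 1 (`CC(C)COc1ccccc1-c1ncc(C(=O)O)c(=O)[nH]1`) gives 0.5 mg/kg and compound 2 (`CCC(C)Oc1ccccc1-c1ncc(C(=O)O)c(=O)[nH]1`) gives 0.5 mg/kg as well, so compound 2 stands level with compound 1. Compound 3 (`CCCCCOc1ccccc1-c1ncc(C(=O)O)c(=O)[nH]1`) has not been measured yet. It carries pentyl in place of sec-butyl on an oxygen on an aromatic ring. Among the compounds with values here, only one measured step bears on this change: sec-butyl in place of isobutyl on that same oxygen gave no change at the digits printed from compound 1 to compound 2 (within the scatter) in this assay for this pair. Within the data shown here, that single step is thin support, and no pentyl compound has been measured, so nothing points up or down. No step beyond the scatter is therefore expected. The estimated step is no change at the digits printed from compound 2 to compound 3 (within the scatter) on this reasoning. Compound 3 is expected at 0.5 mg/kg with an estimated range from 0.2 mg/kg to 1.5 mg/kg as the likely span.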

Compound 3, dose for 50% inhibition: 3 mg/kg
Estimate against measurement, compound 3: 6.0-fold (0.78 log units) below, and the stated range ends below it.
By their numbers in this assay, from the lowest: compounds 1 and 2 (each within the scatter of the next); then compound 3.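

In this assay, the oxygen on the aromatic ring does not treat every alkyl group alike: pentyl in place of sec-butyl gives a 6.0-fold higher number from compound 2 to compound 3 (0.78 log units; beyond the scatter), and pentyl in place of isobutyl gives a 6.0-fold higher number from compound 1 to compound 3 (0.78 log units; beyond the scatter). Isobutyl and sec-butyl could not be told apart, so this position had looked tolerant of change, but pentyl shows that more compound can be needed for the same effect when the group on this oxygen changes. Nothing available here explains why this step occurs.

These compounds cannot separate the extra carbon of pentyl from the absence of a branch near the oxygen, since both change together. Where an unbranched butyl, a longer chain such as hexyl, or a chain ending in an amine would fall remains open.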